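A Longer Saturated Chain on Compound 2

The compounds below may be only part of what the source reports. "The series", "measured", "known", "first", "only" and "open" are said of these compounds alone.

In a functional assay on MCF7 cells (Homo sapiens) for inhibition, read by fluorescence, with a stated time of 72 h (on this read-out lower numbers stand for stronger inhibition of growth and higher numbers for weaker inhibition of growth), compound 1 (`N[C@H]1CC[C@H](Nc2nc(Nc3ccc(Cl)cc3)c3ncn(C4CCCCC4)c3n2)CC1`) gives 2300 nM and compound 2 (`CC(C)=CCn1cnc2c(Nc3cccc(Cl)c3)nc(N[C@H]3CC[C@H](N)CC3)nc21`) gives 4200 nM, so compound 2 stands within the usual scatter of compound 1. Compound 3 (`CCCCCCn1cnc2c(Nc3cccc(Cl)c3)nc(N[C@H]3CC[C@H](N)CC3)nc21`) has not yet been measured. Its structure departs from compound 2 by pentyl in place of 2-methylprop-1-en-1-yl on a saturated chain carbon bound to an aromatic nitrogen, with pentyl in place of 2-methylprop-1-en-1-yl on a saturated chain carbon bound to an aromatic nitrogen. For the measured compounds named here, no measured pair shows this change alone. The expected result in this assay is no shift beyond the scatter, an estimated step of a 1.2-fold lower number from compound 2 to compound 3 (0.08 log units; within the scatter). For compound 3, the estimated value is 3500 nM, with an expected range of 1400 nM to 9000 nM.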

Compound 3, concentration for 50% growth inhibition: 2700 nM
For compound 3 the middle estimate is 1.3-fold (0.11 log units) above the measured one; low and high end bracket the measured number.
By their numbers in this assay, from the lowest: compounds 1, 3 and 2 (each within the scatter of the next).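

For the compounds shown here, this pair gives the first direct reading of a change on a saturated chain carbon bound to an aromatic nitrogen: in this assay pentyl in place of 2-methylprop-1-en-1-yl gives a 1.6-fold lower number from compound 2 to compound 3 (0.19 log units; within the scatter) and the two compounds cannot be told apart. At this place, a chain without the double bond serves as well as one with it. No measurement at hand explains this result. Still open, as far as these compounds go, is whether a longer chain, or a chain ending in an amine or a carboxylic acid, would hold this level of growth inhibition.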